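This account rests on a few compounds, and the source may have more. Where it says the series, first, only, none or still open, it means among the compounds named here.

Measured in a functional assay on U2OS cells (Homo sapiens) for antiproliferative activity, read by MTT assay, with a stated time of 72 h; on this read-out higher numbers stand for weaker inhibition and lower numbers for stronger inhibition:
compound 1 `O=C(CSc1ncccn1)Nc1ccc2nc(NC(=O)c3ccc(C(F)(F)F)cc3)sc2c1`: 28100 nM
compound 2 `O=C(CSc1ccc(Cl)cc1)Nc1ccc2nc(NC(=O)c3ccc4ccccc4c3)sc2c1`: 14500 nM
compound 3 `CCCC(=O)Nc1nc2ccc(NC(=O)CSc3cccc(O)c3)cc2s1`: 10100 nM

Compound 2 stands second highest of the three numbers in this assay; its gaps to compound 3 and to compound 1 both lie within the scatter, so no order among the three is claimed. Compound 4 `O=C(CSc1ccc(Cl)cc1)Nc1ccc2nc(NC(=O)c3ccc(C(F)(F)F)cc3)sc2c1` is not yet measured. It differs from compound 2 in one place: 4-(trifluoromethyl)phenyl in place of naphthalen-2-yl on a carbonyl carbon. Among the measured compounds shown here, no step between measured compounds matches this change. The expected step is a 1.4-fold higher number from compound 2 to compound 4 (0.14 log units; within the scatter), small and toward weaker inhibition, probably within the scatter, because compound 1 gives 28100 nM carrying the same 4-(trifluoromethyl)phenyl on a carbonyl carbon. Compound 4 is estimated at 20000 nM, with a range from 8000 nM to 50000 nM.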

Compound 4, half-maximal inhibitory concentration: 2890 nM
Estimate against measurement, compound 4: 6.9-fold (0.84 log units) above; the whole stated range lies above it.
By their numbers in this assay, from the lowest: compound 4; then compounds 3, 2 and 1 (each within the scatter of the next, the first and the last beyond it).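

In this assay the carbonyl carbon is a position that responds: with 4-chlorophenyl held on the sulfur, 4-(trifluoromethyl)phenyl in place of naphthalen-2-yl gives a 5.0-fold lower number from compound 2 to compound 4 (0.70 log units; beyond the scatter) and not the small step that compound 1 suggested. The group on the sulfur also counts, with 4-chlorophenyl in place of pyrimidin-2-yl giving a 9.7-fold lower number from compound 1 to compound 4 (0.99 log units; beyond the scatter) even though the 4-(trifluoromethyl)phenyl is shared. No measured evidence accounts for either step.

Still open, on these data alone, is how a carboxylic acid or a morpholine on the carbonyl carbon would compare with 4-(trifluoromethyl)phenyl. Also open, as far as these compounds go, is whether the sulfur step holds with naphthalen-2-yl on the carbonyl carbon.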